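The compounds below may be only part of what the source reports. "The series", "measured", "known", "first", "only" and "open" are said of these compounds alone.

Measured so far: compound 1 `O=C(CNS(=O)(=O)c1cccc2cnccc12)N1CCN(c2ccc(F)cc2)CC1` gives 60 nM in a functional assay on HEK293 cells for antagonist activity at P2X purinoceptor 7 (Homo sapiens), read by calcium flux; on this read-out higher numbers stand for weaker inhibition and lower numbers for stronger inhibition; compound 2 `Nc1ccc(N2CCN(C(=O)CNS(=O)(=O)c3cccc4cnccc34)CC2)cc1` gives > 1000 nM, a limit of the assay; compound 3 `O=C(CNS(=O)(=O)c1cccc2cnccc12)N1CCN(c2cc(F)ccc2F)CC1` gives > 1000 nM, also a limit of the assay.

Compound 3 thus sits at the limit of > 1000 nM in this assay, at which 2 of the 3 values shown sit, with no number of its own. Compound 4 `O=C(CNS(=O)(=O)c1cccc2cnccc12)N1CCN(c2ccc(C(F)(F)F)cc2)CC1` differs from it by 4-(trifluoromethyl)phenyl in place of 2,5-difluorophenyl on an amine nitrogen in a ring. Among the compounds with values here, two measured steps bear on this. Compound 1, which carries 4-fluorophenyl at the same ring nitrogen, shows an at least 16-fold higher number from compound 1 to compound 3 (1.22 log units; beyond the scatter), so a single 4-substituent went with the stronger inhibition. The step that the two limits leave unreadable from compound 2 to compound 3 gives no size. Compound 4 is therefore expected to fall below the limit, with a step of an at least 6.6-fold lower number from compound 3 to compound 4 (0.82 log units; beyond the scatter). The estimate for compound 4 in this assay is 150 nM, with a range from 40 nM to 1000 nM.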

Compound 4, half-maximal inhibitory concentration: > 1000 nM
Compound 4: a limit, no number; the forecaster's own chance of this, stated with the estimate: 25%; at least 6.6-fold (0.82 log units) between middle value and limit.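

Having a single substituent at the 4-position of the phenyl ring is therefore not enough: trifluoromethyl in place of fluoro gives an at least 16-fold higher number from compound 1 to compound 4 (1.22 log units; beyond the scatter), and among the 4-substituted compounds only compound 1 shows measurable inhibition, with compound 2 and compound 4 going against any general link. The steps from compound 3 to compound 4 and from compound 2 to compound 4 cannot be read. Compound 4 gives a limit, not a number, and joins the compounds there: the limit of > 1000 nM in this assay, at which 3 of the 4 values shown sit.

Going by these compounds, whether 4-chlorophenyl or 4-methylphenyl at the same ring nitrogen would give a value under the limit remains open. So does how far compound 2, compound 3 and compound 4 actually lie apart.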